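Methyl for chloro on a cytotoxicity series of thiocarbamates

A few compounds are considered here, and "the series" means these few. Any claim that something is new, unique, unknown or untested is made for them only; others in the source may bear on it.

Of the compounds shown here, three of this set have been measured in an ADME assay on MT4 cells (Homo sapiens) for cytotoxicity, read by MTT assay; a higher number here means that more compound is tolerated, a lower number that less compound is tolerated. Compound 1 `O=C1c2ccccc2C(=O)N1CCOC(=S)N(C(=O)c1ccc([N+](=O)[O-])cc1)c1ccc(Cl)cc1` sits at the limit of the assay, (the limit of > 100000 nM in this assay, at which 1 of the 3 values shown sits), and gives only > 100000 nM, not a number. Compound 2 `Cc1ccc(N(C(=O)c2ccc([N+](=O)[O-])cc2)C(=S)OCCN2C(=O)c3ccccc3C2=O)cc1` gives 58000 nM in this assay. The change methyl in place of chloro on an aromatic carbon is therefore read as an at least 1.7-fold lower number from compound 1 to compound 2 (0.23 log units; that floor lies within the scatter). Compound 3 `O=C1c2ccccc2C(=O)N1CCOC(=S)N(C(=O)c1ccc(F)cc1F)c1ccc(Cl)cc1` gives 52000 nM in this assay; its core differs from that of compound 1 by 2,4-difluorophenyl in place of 4-nitrophenyl on a carbonyl carbon, a step of an at least 1.9-fold lower number from compound 1 to compound 3 (0.28 log units; that floor lies within the scatter). The values of compound 2 and compound 3 lie within the scatter of each other.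

Compound 4 `Cc1ccc(N(C(=O)c2ccc(F)cc2F)C(=S)OCCN2C(=O)c3ccccc3C2=O)cc1` has not been measured. It differs from compound 3 by methyl in place of chloro on an aromatic carbon, the same change as made from compound 1 to compound 2, at the same place in the same words. Since that earlier step rests on a limit and its floor lies within the scatter, the step from compound 3 to compound 4 is expected to be small, about a 1.2-fold lower number from compound 3 to compound 4 (0.06 log units; within the scatter). Compound 4 is estimated at 45000 nM in this assay, between 20000 nM and 100000 nM.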

Compound 4, half-maximal cytotoxic concentration: 20000 nM
The estimate for compound 4 lay 2.3-fold (0.35 log units) above the measured number; the measured number falls inside the stated range.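

In this assay, methyl in place of chloro gives a 2.6-fold lower number from compound 3 to compound 4 (0.41 log units; beyond the scatter), and 2,4-difluorophenyl in place of 4-nitrophenyl gives a 2.9-fold lower number from compound 2 to compound 4 (0.46 log units; beyond the scatter). Methyl for chloro thus has a measured size on the core of compound 3, while its step on the core of compound 1 is only a floor, so a fixed size for this change across cores is neither shown nor ruled out: the same change on two cores in this assay, an at least 1.7-fold lower number (0.23 log units; that floor lies within the scatter) from compound 1 to compound 2 and a 2.6-fold lower number (0.41 log units; beyond the scatter) from compound 3 to compound 4; the limit leaves it open whether they differ. The same reading applies to the change on the carbonyl carbon, whose second step has a measured size and whose first is only a floor: the same change on two cores in this assay, an at least 1.9-fold lower number (0.28 log units; that floor lies within the scatter) from compound 1 to compound 3 and a 2.9-fold lower number (0.46 log units; beyond the scatter) from compound 2 to compound 4; the limit leaves it open whether they differ.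

Still open, as far as these compounds go, is what an amine or a carboxylic acid in place of chloro, or a longer chain in place of methyl, would give in this assay. Also open, from the compounds shown here alone, is whether methyl in place of chloro would give a step of similar size on a third core.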